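The source may report more compounds than this note shows. Statements on the series, on what has been measured and on what is new or still open speak of the compounds shown alone.

Working notes on the series. In a functional assay on the whole organism with Canis familiaris (Canis lupus familiaris) as the target, at a dose of 2 mg/kg by the intravenous route (a lower number here means a weaker effect, a higher number a stronger effect of the compound at the dose given), compound 1 `Cc1nc2c(OCc3ccccc3)cccn2c1N` gives 97%. In this assay compound 2 `CC(=O)Nc1c(C)nc2c(OCc3ccccc3)cccn12` gives 24%, and compound 3 `CCCNc1c(C)nc2c(OCc3ccccc3)cccn12` gives 12%. Compound 3 stands lowest of the three numbers, with compound 2 nearest and compound 1 furthest, both beyond the scatter. Within the data shown here, the steps leading into it are a number 85 percentage points lower from compound 1 to compound 3 (beyond the scatter) and a number 12 percentage points lower from compound 2 to compound 3 (beyond the scatter); the related step of a number 73 percentage points lower from compound 1 to compound 2 (beyond the scatter) points the same way, so in this small set each replacement of hydrogen on a nitrogen on an aromatic ring by a carbon group has cost inhibition, with no compound going against it.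

Compound 4 `Cc1nc2c(OCc3ccccc3)cccn2c1N(C)C` is not yet measured. It differs from compound 3 as follows: dimethylamino in place of propylamino on an aromatic carbon. The nitrogen again carries no hydrogen, as in compound 3 and compound 2, so the large loss of a number 85 percentage points lower from compound 1 to compound 3 (beyond the scatter) is not expected to be recovered. The propyl-to-dimethyl exchange is expected to give a step of a number 3 percentage points higher from compound 3 to compound 4 (within the scatter) that stays within the scatter. Compound 4 is therefore estimated at 15%, in the range 0% to 40%.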

Compound 4, a percentage reported as inhibition, in the whole organism at one dose (the size of the read-out at that dose, not a potency): 85%
The estimate for compound 4 lay 70 percentage points below the measured number; measured number above the stated range.
By their numbers in this assay, from the lowest: compound 3; then compound 2; then compound 4; then compound 1.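

In this assay, the position on the aromatic carbon of the five-membered aromatic ring accepts a nitrogen with two carbon groups: dimethylamino, with 0 hydrogen-bond donors, gives a number 73 percentage points higher from compound 3 to compound 4 (beyond the scatter) and a number 61 percentage points higher from compound 2 to compound 4 (beyond the scatter). Compound 4 thus goes against the earlier pattern that carbon groups on this nitrogen cost inhibition, since the drop in this one case is only a number 12 percentage points lower from compound 1 to compound 4 (beyond the scatter), a modest step beside those seen with propylamino and acetamido. Nothing at hand bears on why dimethylamino behaves so differently from propylamino.

Going by these compounds, it remains open whether the high reading is particular to dimethylamino or extends to other groups at this position. Methylamino and diethylamino on the same carbon would show whether the number of carbon groups on the nitrogen or their length goes with the change.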